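This account rests on a few compounds, and the source may have more. Where it says the series, first, only, none or still open, it means among the compounds named here.

Measured in a functional assay on SK-BR-3 cells (Homo sapiens) for antiproliferative activity, read by MTT assay, with a stated time of 72 h; a higher number here means a weaker inhibitor, a lower number a stronger inhibitor:
compound 1 `CCN1CCN(c2cc(C)c3cc(NC(=O)c4ccccc4C)ccc3n2)CC1`, 29200 nM
compound 2 `CCc1ccccc1C(=O)Nc1ccc2nc(N3CCN(CC)CC3)cc(C)c2c1`, 23900 nM
compound 3 `CCN1CCN(c2cc(C)c3cc(NC(=O)c4ccc(OC)cc4)ccc3n2)CC1`, 9000 nM

Compound 3 stands lowest of the three numbers in this assay. Its nearest neighbour is compound 2, with a 2.7-fold lower number from compound 2 to compound 3 (0.42 log units; beyond the scatter); the gap to compound 1 is a little wider, a 3.2-fold lower number from compound 1 to compound 3 (0.51 log units; beyond the scatter). Between compound 1 and compound 2 the difference is a 1.2-fold lower number from compound 1 to compound 2 (0.09 log units; within the scatter).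

Compound 4 `CCN1CCN(c2cc(C)c3cc(NC(=O)c4cc(Cl)cc(Cl)c4)ccc3n2)CC1` is not yet measured. It differs from compound 3 in one place: 3,5-dichlorophenyl in place of 4-methoxyphenyl on a carbonyl carbon. The two measured steps that touch the group on the carbonyl carbon both end at compound 3 and replace 2-methylphenyl or 2-ethylphenyl with 4-methoxyphenyl; neither involves 3,5-dichlorophenyl. Among the measured compounds shown here, they show only that changing this group shifts the number beyond the scatter but by a modest amount, and give no direction for the present change. The expected step is therefore no change at the digits printed from compound 3 to compound 4 (within the scatter), with no confident direction. Compound 4 is estimated at 9000 nM, within a range of 3000 nM to 30000 nM.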

Compound 4, half-maximal inhibitory concentration: 2660 nM
The estimate for compound 4 lay 3.4-fold (0.53 log units) above the measured number; the whole stated range lies above it.
By their numbers in this assay, from the lowest: compound 4; then compound 3; then compounds 2 and 1 (each within the scatter of the next).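

In this assay, the group on the carbonyl carbon can take the number lower than compound 3 reached: 3,5-dichlorophenyl in place of 4-methoxyphenyl gives a further drop (a 3.4-fold lower number from compound 3 to compound 4 (0.53 log units; beyond the scatter)). Against the 2-ethylphenyl and 2-methylphenyl amides the change is wider (a 9.0-fold lower number from compound 2 to compound 4 (0.95 log units; beyond the scatter); an 11-fold lower number from compound 1 to compound 4 (1.04 log units; beyond the scatter)), and the last of these is the only large step in the set, so this single position spans more range than the earlier compounds showed. Nothing available explains why this change lowers the number.

The compounds shown leave open whether one chlorine on the phenyl would serve as well as two, and how a phenyl carrying an amine or a carboxylic acid would read at this position. They also leave open whether the step would hold with a longer chain in place of the ethyl group on the shared core.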